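Ester, Amide and Free Acid on a Shared Core

This account rests on a few compounds, and the source may have more. Where it says the series, first, only, none or still open, it means among the compounds named here.

Compound 1 `CCCCCCOC(=O)/C=C/[C@H]1C[C@@H](O)[C@@H](O)C1`: > 350000 nM
Compound 2 `CCNC(=O)/C=C/[C@H]1C[C@@H](O)[C@@H](O)C1`: > 250000 nM

Of the compounds shown here, two built on the same core have been tested in an ADME assay on S2 cells (Drosophila melanogaster) for cytotoxicity, read by MTT assay; on this read-out lower numbers stand for an effect already at smaller amounts and higher numbers for an effect only at larger amounts of compound. In this assay compound 1 gives only a limit, > 350000 nM, and not a number. In this assay compound 2 likewise gives only a limit, > 250000 nM. Going by the values given here, compound 2 therefore stands at a limit, as does the one other value shown, so neither compound reaches a measurable effect within the tested range, and no step between them can be sized.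

Compound 3 `O=C(O)/C=C/[C@H]1C[C@@H](O)[C@@H](O)C1` has not yet been measured. It differs from compound 2 by hydroxy in place of ethylamino on a carbonyl carbon. Among the compounds with values here, with no measured step between any two compounds, the only guide is that compound 2 sits at a limit of > 250000 nM in this assay, at which 1 of the 2 values shown sits, and compound 1 at a limit (the limit of > 350000 nM in this assay, at which 1 of the 2 values shown sits). Compound 3 is expected to behave alike, with an expected step from compound 2 of a step that the limit leaves unreadable from compound 2 to compound 3, that is, none beyond the scatter. For compound 3 the estimate in this assay is 300000 nM, within a range from 100000 nM to 1000000 nM, most probably reported once more only as a limit.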

Compound 3, half-maximal effective concentration: > 350000 nM
Compound 3: no number, only a limit; the forecaster's own chance of this, stated with the estimate: 85%; middle value at least 1.1-fold (0.06 log units) away from the limit.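

In this assay compound 3 gives only a limit, as do compound 1 and compound 2, so the steps from compound 1 and compound 2 to compound 3 cannot be read. The compounds shown leave open at what concentration, if any, the ester, the amide or the free acid would show a measurable effect.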